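The source may report more compounds than this note shows. Statements on the series, on what has been measured and on what is new or still open speak of the compounds shown alone.

The benzyloxy analogue compound 3 `c1ccc(COc2cccc(-c3cn(C4CN5CCC4CC5)nn3)c2)cc1` sits second highest among the three numbers in an assay on HEK293 cells for displacement of a labelled ligand from Neuronal acetylcholine receptor; alpha3/beta4 (Homo sapiens), read by scintillation counting, with a stated time of 120 min; on this read-out lower numbers stand for stronger inhibition and higher numbers for weaker inhibition: compound 3 gives 7.57 nM, against compound 2 `Oc1ccc(-c2cn([C@@H]3CN4CCC3CC4)nn2)cc1` at 2.48 nM and compound 1 `Oc1ccc(-c2cn([C@H]3CN4CCC3CC4)nn2)cc1` at 138 nM. Compound 4 `c1ccc(COc2cccc(-c3cn([C@H]4CN5CCC4CC5)nn3)c2)cc1` is the next step: the two compounds have the same atoms and bonds; at least one stereo element is drawn with a configuration in one of them and without one in the other: 1 of 3 stereo elements differ; a stereocentre at a saturated ring carbon is drawn without a configuration in compound 3 and R in compound 4. Going by the values given here, the one measured step that bears on it is a 56-fold lower number from compound 1 to compound 2 (1.75 log units; beyond the scatter), a large change attributable only to the fact that one of compounds 1 and 2 is drawn with a defined configuration and the other without, at the place where they differ. The stereocentre drawn R in compound 1 is the same one that compound 4 fixes, while compound 3 leaves it undefined, so the number of compound 3 is read as that of a mixture lying close to its stronger component. Fixing the configuration to R is expected to move the number upward, toward weaker inhibition, by roughly a 20-fold higher number from compound 3 to compound 4 (1.30 log units; beyond the scatter) in this assay. Compound 4 is accordingly estimated at 150 nM in this assay, with a range of 40 nM to 600 nM. Among the compounds with values here, only two compounds support the direction, so the size stays uncertain.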

Compound 4, inhibition constant: 631 nM
Compound 4: the middle estimate sits 4.2-fold (0.62 log units) below what was measured; the measured number lies above the stated range.
By their numbers in this assay, from the lowest: compound 2; then compound 3; then compound 1; then compound 4.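

In this assay there is an 83-fold higher number from compound 3 to compound 4 (1.92 log units; beyond the scatter), so the higher number for the carbon drawn R is no longer confined to the pair of compound 1 and compound 2 and now also appears with a benzyloxy group on the shared core. Across the two pairs that vary this stereocentre, the R drawing goes with the higher number, and no compound shown goes against this. With atoms and bonds unchanged, the step can be traced to one difference only: the fact that one of compounds 3 and 4 is drawn with a defined configuration and the other without, at the place where they differ.

The benzyloxy compound drawn S lies outside the compounds shown, so its number and its share in the value of compound 3 remain open. Also open, on these data alone, is whether the R form keeps this disadvantage when an amine or a carboxylic acid replaces the benzyloxy group.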